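This account rests on a few compounds, and the source may have more. Where it says the series, first, only, none or still open, it means among the compounds named here.

Measured compounds: compound 1 `Cc1ccc2nc(C(=O)Nc3c(F)cc(-c4cccc(F)c4)cc3F)c(C)c(O)c2c1` gives 90500 nM; compound 2 `CCc1ccc2nc(C(=O)Nc3c(F)cc(-c4cccc(F)c4)cc3F)c(C)c(O)c2c1` gives 8130 nM; compound 3 `CCOc1ccc2nc(C(=O)Nc3c(F)cc(-c4cccc(F)c4)cc3F)c(C)c(C(=O)O)c2c1` gives 14900 nM, all in a functional assay on A-375 cells (Homo sapiens) for antiproliferative activity, read by MTT assay, with a stated time of 24 h; on this read-out higher numbers stand for weaker inhibition and lower numbers for stronger inhibition.

The one counted step among these is hydrogen in place of methyl on a saturated chain carbon bound to an aromatic carbon, which in this assay reads an 11-fold higher number from compound 2 to compound 1 (1.05 log units; beyond the scatter). Compound 4 `COc1ccc2nc(C(=O)Nc3c(F)cc(-c4cccc(F)c4)cc3F)c(C)c(C(=O)O)c2c1` differs from compound 3 by hydrogen in place of methyl on a saturated chain carbon bound to an oxygen on an aromatic ring. This is the same kind of change, not the same: in compound 2 the saturated chain carbon is bound to an aromatic carbon, in compound 3 to an oxygen on an aromatic ring. The difference between the cores of compound 2 and compound 3 is not broken down here; their values lie within the scatter of each other. Because the earlier change gave an 11-fold higher number from compound 2 to compound 1 (1.05 log units; beyond the scatter), a weakening is expected for compound 4, estimated at a 2.3-fold higher number from compound 3 to compound 4 (0.37 log units; beyond the scatter), smaller since the surroundings differ. Compound 4 is thus expected near 35000 nM, between 12000 nM and 120000 nM.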

Compound 4, half-maximal inhibitory concentration: > 100000 nM
Compound 4: no number, only a limit; the forecaster's own chance of this, stated with the estimate: 15%; at least 2.8-fold (0.45 log units) between middle value and limit.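

In this assay, hydrogen in place of methyl on the ethoxy group of compound 3 weakens inhibition: an at least 6.7-fold higher number from compound 3 to compound 4 (0.82 log units; beyond the scatter). Compound 4 gives only a limit of the assay, > 100000 nM, and not a number. The change weakens inhibition on both cores, which shows that its direction carries over in these two pairs, but it does not show whether its size carries over: the same change on two cores in this assay, an 11-fold higher number (1.05 log units; beyond the scatter) from compound 2 to compound 1 and an at least 6.7-fold higher number (0.82 log units; beyond the scatter) from compound 3 to compound 4; the limit leaves it open whether they differ

Two pairs give no rule for the series as a whole. The compounds shown leave open whether a chain longer than ethyl or ethoxy would strengthen inhibition further, and how an amine at this place would read.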